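A few compounds are considered here, and "the series" means these few. Any claim that something is new, unique, unknown or untested is made for them only; others in the source may bear on it.

Compound 1, `Cc1ccccc1-c1nc(CN2CCC(C(=O)NCCCN3CCC(C(C)C)CC3)CC2)c(C)o1`: in a physicochemical assay for solubility, in phosphate buffer, measured as kinetic solubility, at pH 7.4 (a higher number here means a more soluble compound, a lower number a less soluble compound), compound 1 reaches only the assay limit, > 71 ug/mL.
Compound 2, `Cc1cccc(Cl)c1-c1nc(CN2CCC(C(=O)NCCCN3CCC(C(C)C)CC3)CC2)c(C)o1`: in this assay compound 2 also stops at a limit, > 76 ug/mL.
Compound 3, `Cc1cccc(F)c1-c1nc(CN2CCC(C(=O)NCCCN3C[C@H](C)C[C@H](C)C3)CC2)c(C)o1`: in this assay compound 3 likewise gives a limit, > 72 ug/mL.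

Compound 3 therefore stands with only a limit and no number, as do both other measured compounds; each value is a limit of the assay: the limit of > 71 ug/mL in this assay, at which 1 of the 3 values shown sits, (the limit of > 72 ug/mL in this assay, at which 1 of the 3 values shown sits), (the limit of > 76 ug/mL in this assay, at which 1 of the 3 values shown sits). Among the measured compounds shown here, the one measured step between compounds differing in a single place, a step that the two limits leave unreadable from compound 1 to compound 2, has a limit at both of its ends and gives no readable size.

Compound 4, `Cc1ccc(-c2nc(CN3CCC(C(=O)NCCCN4C[C@H](C)C[C@H](C)C4)CC3)c(C)o2)c(C)c1`, is the next member. The change from compound 3 is 2,4-dimethylphenyl in place of 2-fluoro-6-methylphenyl on an aromatic carbon. For the measured compounds named here, no measured step in this assay bears on this change: the only step available concerns a chloro in place of hydrogen and is itself unreadable. The expectation for compound 4 thus rests on the three limits alone, all sitting at the same ceiling.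

Compound 4 is expected to give about 80 ug/mL in this assay, within 40 ug/mL to 160 ug/mL. The expected step is a step that the limit leaves unreadable from compound 3 to compound 4, and the most likely outcome is again a limit rather than a number.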

Compound 4, solubility: > 71 ug/mL
Compound 4: no number, only a limit (the forecaster's own chance of this, stated with the estimate: 70%); the middle value does not contradict the limit.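

Compound 3 and compound 4 both stop at a limit in this assay, so the step between them, 2,4-dimethylphenyl in place of 2-fluoro-6-methylphenyl, cannot be read. The compounds shown leave open what solubility number lies behind each limit, and whether this change or the chloro change moves solubility at all.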